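The compounds below may be only part of what the source reports. "The series", "measured", "known", "first", "only" and "open" are said of these compounds alone.

In a functional assay on SW-620 cells (Homo sapiens) for cytotoxicity, read by sulforhodamine B assay, with a stated time of 48 h (on this read-out lower numbers stand for stronger inhibition and higher numbers for weaker inhibition), compound 1 `C[C@H]1CC[C@@H]2[C@@H](OC(=O)[C@]23CC(c2ccccc2F)=NO3)[C@]2(C)C(=O)C=C[C@@]12O` gives 11000 nM, and compound 2 `Cc1ccccc1C1=NO[C@]2(C1)C(=O)O[C@@H]1[C@H]2CC[C@H](C)[C@]2(O)C=CC(=O)[C@@]12C` gives 5000 nM, the lower of the two numbers. Compound 3 `Cc1cccc(C2=NO[C@]3(C2)C(=O)O[C@@H]2[C@H]3CC[C@H](C)[C@]3(O)C=CC(=O)[C@@]23C)c1` differs from compound 2 as follows: 3-methylphenyl in place of 2-methylphenyl on a carbon with a double bond to nitrogen. The methyl group stays, and 3-methylphenyl stands in place of 2-methylphenyl. Going by the values given here, the only measured step, a 2.2-fold lower number from compound 1 to compound 2 (0.34 log units; beyond the scatter), exchanged fluoro for methyl and is modest, and no measured step compares these two groups. No shift beyond the scatter in this assay is therefore expected, in either direction, and the estimated step is no change at the digits printed from compound 2 to compound 3 (within the scatter). Compound 3 is expected at 5000 nM, within an estimated range of 2200 nM to 11500 nM.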

Compound 3, half-maximal inhibitory concentration in the SW-620 assay: 15000 nM
Estimate against measurement, compound 3: 3.0-fold (0.48 log units) below; the whole stated range lies below it.
By their numbers in the SW-620 assay, from the lowest: compound 2; then compounds 1 and 3 (each within the scatter of the next).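

Where the methyl group sits on the phenyl ring matters here: in the SW-620 assay compound 2 gives 5000 nM and compound 3 gives 15000 nM, and the change to 3-methylphenyl gives a 3.0-fold higher number from compound 2 to compound 3 (0.48 log units; beyond the scatter) against the 2-methylphenyl group. Replacing 2-fluorophenyl with 3-methylphenyl gives only a 1.4-fold higher number from compound 1 to compound 3 (0.13 log units; within the scatter) in the same assay, so those two groups are not told apart. In a physicochemical assay for lipophilicity (on this read-out higher numbers stand for higher lipophilicity and lower numbers for lower lipophilicity), compound 2 gives 1.86 and compound 3 gives 1.86, so the partition coefficient shows no change at the digits printed from compound 2 to compound 3 (within the scatter) even though the cytotoxicity number shifts between these two compounds. Going by these compounds, whether a methoxy group or an amine on the phenyl ring would give a lower number remains open, as does any effect of a methyl group elsewhere on that ring. No evidence at hand accounts for the shift between the two methylphenyl compounds.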